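The source may hold more compounds than are shown below. What is called first, only, known or untested is meant among the compounds shown, and "the series" means these compounds.

Measured compounds: compound 1 `Cc1ccc(OS(=O)(=O)c2ccc(N3CCN(C)C3=O)cc2)c(C)c1`, compound 2 `COc1cc(OS(=O)(=O)c2ccc(N3CCN(C)C3=O)cc2)cc(OC)c1OC` and compound 3 `CCCN1CCN(c2ccc(S(=O)(=O)Oc3ccc(C)cc3C)cc2)C1=O`. In a functional assay on MCF7 cells (Homo sapiens) for antiproliferative activity, read by sulforhodamine B assay, with a stated time of 48 h (on this read-out lower numbers stand for stronger inhibition and higher numbers for weaker inhibition), compound 1 gives 2500 nM, compound 2 gives 120 nM and compound 3 gives 1500 nM.

Compound 3 sits second highest of the three numbers. Its nearest neighbour is compound 1, separated by a 1.7-fold lower number from compound 1 to compound 3 (0.22 log units; within the scatter), a step that is within the scatter; its furthest is compound 2, whose number lies well beyond the scatter from that of compound 3.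

Compound 4 `CCCN1CCN(c2ccc(S(=O)(=O)Oc3ccc(OC)cc3)cc2)C1=O` differs from compound 3 in one place: 4-methoxyphenyl in place of 2,4-dimethylphenyl on an oxygen. Within the data shown here, no measured step covers this change. Among the measured compounds shown here, the only guide is the pair compound 1 and compound 2, which share the rest of the structure and differ in the ring on the same oxygen: compound 2 carries methoxy groups and gives the lowest number, compound 1 carries methyl groups and gives the highest. On that basis compound 4 is expected to give a lower number than compound 3 in this assay, by about a 2.1-fold lower number from compound 3 to compound 4 (0.33 log units; beyond the scatter), though the single methoxy may not bring it as far as compound 2. The estimate for compound 4 is 700 nM, with a range from 200 nM to 2500 nM.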

Compound 4, half-maximal inhibitory concentration: 20000 nM
The estimate for compound 4 lay 29-fold (1.46 log units) below the measured number; the measured number lies above the stated range.
By their numbers in this assay, from the lowest: compound 2; then compounds 3 and 1 (each within the scatter of the next); then compound 4.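

Putting 4-methoxyphenyl in place of 2,4-dimethylphenyl on the oxygen whose other neighbour is the sulfonyl sulfur gives a 13-fold higher number from compound 3 to compound 4 (1.12 log units; beyond the scatter) in this assay. Among these compounds, the earlier pair showed only that changing this ring can lower the number, with compound 1 at 2500 nM and compound 2 at 120 nM; the new step shows that it can also raise it sharply, and that a methoxy group on this ring does not by itself go with a lower number. No measurement offered here accounts for the size or direction of this step.

The compounds shown leave open whether the rise goes with losing the methyl groups or with gaining the methoxy group, which a plain phenyl or a chlorophenyl on this oxygen could help separate. Also open, from the compounds shown here alone, is whether the ring of compound 2 would give a low number on the core of compound 3.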